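The source may hold more compounds than are shown below. What is called first, only, known or untested is meant among the compounds shown, and "the series" means these compounds.

Among the measured compounds shown here, in a functional assay on SF-295 cells (Homo sapiens) for inhibition, read by sulforhodamine B assay, with a stated time of 48 h (on this read-out higher numbers stand for weaker inhibition of growth and lower numbers for stronger inhibition of growth), compound 1 `COc1cc(-c2nn(-c3cccc(NC(=O)c4cccc(C(F)(F)F)c4)c3)cc2-c2ccncc2)ccc1Cl` gives 3000 nM, the higher of the two numbers measured so far. Compound 2 `COc1cc(-c2nn(-c3cccc(NC(=O)Nc4cccc(C(F)(F)F)c4)c3)cc2-c2ccncc2)ccc1Cl` gives 1130 nM. Compound 3 `COc1cc(-c2nn(-c3cccc(NC(=O)Nc4ccc(Cl)c(C(F)(F)F)c4)c3)cc2-c2ccncc2)ccc1Cl` has not yet been measured. It differs from compound 1 by (4-chloro-3-(trifluoromethyl)phenyl)amino in place of 3-(trifluoromethyl)phenyl on a carbonyl carbon. For the measured compounds named here, the one measured step that bears on this change is a 2.7-fold lower number from compound 1 to compound 2 (0.42 log units; beyond the scatter), a modest step in which (3-(trifluoromethyl)phenyl)amino enters at the same place. Going by the values given here, no measured step isolates the chloro on the entering group, so its contribution remains unknown. The expected step in this assay is therefore a 3.3-fold lower number from compound 1 to compound 3 (0.52 log units; beyond the scatter), similar in size and toward a lower number. Compound 3 is estimated at 900 nM, with an expected range from 350 nM to 2300 nM.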

Compound 3, concentration for total growth inhibition: 2540 nM
The estimate for compound 3 lay 2.8-fold (0.45 log units) below the measured number; the measured number lies above the stated range.
By their numbers in this assay, from the lowest: compound 2; then compounds 3 and 1 (each within the scatter of the next).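

Among the compounds shown here, the chloro on the entering group, which no earlier step isolated, can now be read in this assay: chloro in place of hydrogen on an aromatic carbon gives a 2.2-fold higher number from compound 2 to compound 3 (0.35 log units; beyond the scatter), a modest step that runs against the one gained with the amino-linked group of compound 2. The full change on the carbonyl carbon gives a 1.2-fold lower number from compound 1 to compound 3 (0.07 log units; within the scatter), so with the chloro present, the step seen from compound 1 to compound 2 does not carry over. Nothing measured here says why the chloro acts this way.

On these data alone, it remains open whether a fluoro, a methyl or a methoxy on that aromatic carbon would follow the chloro. As far as these compounds go, it is also open whether the chloro would give the same step on the carbonyl-linked aryl group of compound 1.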